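Pyridinyl for Fluorophenyl in a Glycine Transporter Series

The source may hold more compounds than are shown below. What is called first, only, known or untested is meant among the compounds shown, and "the series" means these compounds.

compound 1, `CCN1CCCC(NC(=O)c2c(OC)cc(C(F)(F)F)cc2C(F)(F)F)(c2ccccc2)C1`: 230 nM
compound 2, `Cc1cc(C(F)(F)F)ccc1C(=O)NC1(c2ccccc2)CCCN(C)C1`: 320 nM
compound 3, `COc1cc(C(F)(F)F)cc(SC)c1C(=O)NC1(c2ccc(F)cc2)CCCN(C)C1`: 26 nM

All three were measured in an assay on cells for inhibition of sodium- and chloride-dependent glycine transporter 1 (Homo sapiens); a lower number here means that less compound is needed, a higher number that more compound is needed for the effect. Compound 3 stands lowest of the three; compound 1 and compound 2 both lie above it by margins beyond the usual scatter, so compound 3 is the most potent of the measured set.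

Compound 4, `COc1cc(C(F)(F)F)cc(SC)c1C(=O)NC1(c2cccnc2)CCCN(C)C1`, has not been measured. It differs from compound 3 in one place: pyridin-3-yl in place of 4-fluorophenyl on a saturated ring carbon. Among the measured compounds shown here, no measured pair shows this change, so its effect cannot be read from the data. A modest rise in the number is expected, likely a little beyond the scatter. Compound 4 is expected to give 70 nM, within a range from 25 nM to 250 nM. The expected step is a 2.7-fold higher number from compound 3 to compound 4 (0.43 log units; beyond the scatter).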

Compound 4, half-maximal effective concentration: 54 nM
Beside the measured number, compound 4's estimate is 1.3-fold (0.11 log units) above it; the measured number falls inside the stated range.
By their numbers in this assay, from the lowest: compound 3; then compound 4; then compounds 1 and 2 (each within the scatter of the next).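

In this assay, this saturated ring carbon accepts pyridin-3-yl in place of 4-fluorophenyl at a modest cost (a 2.1-fold higher number from compound 3 to compound 4 (0.32 log units; beyond the scatter)). Among the compounds shown here, it is the first comparison that differs in one place, and it shows that this position keeps much of its potency when the carbon-only aromatic ring gives way to one with a ring nitrogen. Nothing at hand explains the size of this step.

From the compounds shown here alone, whether pyridin-4-yl or pyrimidin-5-yl on this carbon would read closer to compound 3 or to compound 4 stays open.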